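Swapping the chain for a pyrimidin-2-yl: expected cytotoxicity

The source may report more compounds than this note shows. Statements on the series, on what has been measured and on what is new or still open speak of the compounds shown alone.

Compound 1 `CN1C(=S)[C@@H](NC(=O)c2n[nH]c(Cc3ccccc3)n2)COc2ccccc21`: > 50000 nM
Compound 2 `CN1C(=S)[C@@H](NC(=O)c2nc(Cc3ccccc3)n(CCCCCC#N)n2)COc2ccccc21`: > 100000 nM
Compound 3 `CN1C(=S)[C@@H](NC(=O)c2nc(Cc3ccccc3)n(C3CCN(C(=O)OC(C)(C)C)CC3)n2)COc2ccccc21`: > 100000 nM

Every value shown so far in a toxicity assay on HT-29 cells (Homo sapiens) for cytotoxicity (on this read-out higher numbers stand for lower toxicity in this test and lower numbers for higher toxicity in this test), is a limit of the assay rather than a number. Compound 1 stops at the limit > 50000 nM. Compound 2 stops at the limit > 100000 nM. Compound 3 likewise stops at the limit > 100000 nM. Compound 2 therefore stands at the limit of > 100000 nM in this assay, at which 2 of the 3 values shown sit, together with compound 3, while compound 1 sits at the limit of > 50000 nM in this assay, at which 1 of the 3 values shown sits. Among the measured compounds shown here, the single step between compounds differing in one place, a step that the two limits leave unreadable from compound 1 to compound 2, cannot be sized because both ends are limits.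

Compound 4 `CN1C(=S)[C@@H](NC(=O)c2nc(Cc3ccccc3)n(-c3ncccn3)n2)COc2ccccc21` differs from compound 2 by pyrimidin-2-yl in place of 5-cyanopentyl on an aromatic nitrogen. For the measured compounds named here, the only step that bears on this change is the unreadable one from compound 1 to compound 2, so no measured step gives a direction or a size. Compound 4 is therefore expected to show no step beyond the scatter of this assay, with a number no higher from compound 2 to compound 4 (the limit leaves the size open) as the expected step. Compound 4 is estimated at 100000 nM, in a range from 50000 nM to 200000 nM, most likely reported again as a limit.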

Compound 4, half-maximal cytotoxic concentration: > 100000 nM
Compound 4: a limit, no number; the forecaster's own chance of this, stated with the estimate: 85%; the middle value sits exactly at the limit.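

In this assay compound 4 gives > 100000 nM, a limit and not a number. That limit is a shared one: the limit of > 100000 nM in this assay, at which 3 of the 4 values shown sit. Among the compounds shown here, both ends are limits, so neither the step from compound 1 to compound 4 nor the one from compound 2 to compound 4 can be read. The compounds shown leave open whether the group on the aromatic nitrogen alters the half-maximal cytotoxic concentration at all.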